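Swapping the heteroaryl on sulfur: from triazole to imidazole

This account rests on a few compounds, and the source may have more. Where it says the series, first, only, none or still open, it means among the compounds named here.

Of the compounds shown here, three sharing one core have been measured in a functional assay on HT-29 cells (Homo sapiens) for cytotoxicity, read by MTT assay, with a stated time of 24 h, tested at 16 ug/mL; a higher number here means a stronger effect of the compound at the concentration tested, a lower number a weaker effect. Compound 1, with the structure `Cn1c(-c2ccc(NC(=O)CCl)cc2)nc(-c2ccccc2)c1-c1ccccc1`, gives 23.7%. Compound 2, `Cn1c(-c2ccc(NC(=O)CSc3nc4ccccc4o3)cc2)nc(-c2ccccc2)c1-c1ccccc1`, gives 56.2%, and compound 3, `Cn1cnnc1SCC(=O)Nc1ccc(-c2nc(-c3ccccc3)c(-c3ccccc3)n2C)cc1`, gives 59.1%. Compound 3 has the highest of the three numbers, but its gap to compound 2 is within the scatter, so the two cannot be ranked against each other; only compound 1 lies clearly lower, as the steps of a number 32.5 percentage points higher from compound 1 to compound 2 (beyond the scatter) and a number 35.4 percentage points higher from compound 1 to compound 3 (beyond the scatter) show.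

Compound 4, `Cn1ccnc1SCC(=O)Nc1ccc(-c2nc(-c3ccccc3)c(-c3ccccc3)n2C)cc1`, has not yet been measured. It differs from compound 3 in one place: 1-methyl-1H-imidazol-2-yl in place of 4-methyl-4H-1,2,4-triazol-3-yl on a sulfur. For the measured compounds named here, the one measured step that bears on this, a swap of one heteroaryl for another on the sulfur, is a number 2.9 percentage points higher from compound 2 to compound 3 (within the scatter), within the scatter. On that basis the step is expected to be a number 2.1 percentage points lower from compound 3 to compound 4 (within the scatter), with no change beyond the scatter. Compound 4 is therefore estimated at 57%, in the range 44% to 70%.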

Compound 4, a percentage reported as activity, at one concentration (the size of the read-out at that concentration, not a potency): 36.5%
Beside the measured number, compound 4's estimate is 20.5 percentage points above it, and the stated range ends above it.
By their numbers in this assay, from the lowest: compound 1; then compound 4; then compounds 2 and 3 (each within the scatter of the next).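

The ring on the sulfur does matter: the earlier swap of one heteroaryl for another stayed within the scatter, but 1-methyl-1H-imidazol-2-yl in place of 4-methyl-4H-1,2,4-triazol-3-yl gives a number 22.6 percentage points lower from compound 3 to compound 4 (beyond the scatter) and, set against the 1,3-benzoxazol-2-yl group, a number 19.7 percentage points lower from compound 2 to compound 4 (beyond the scatter) as well. So the two earlier groups do not show that any heteroaryl on this sulfur serves equally well, although replacing chloro with the new group still gives a number 12.8 percentage points higher from compound 1 to compound 4 (beyond the scatter) in this series. The two rings differ in that the one entering has 4 carbon and 2 nitrogen atoms where the one leaving has 3 of each, but nothing available explains why this exchange lowers the number.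

Still open, as far as these compounds go, is how a simple amine such as piperidine, placed on the saturated chain carbon bound to a carbonyl carbon in place of the sulfanyl group, would compare. Also open, from the compounds shown here alone, is how a plain phenyl ring on the sulfur would compare with these heteroaryl groups.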